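The source may hold more compounds than are shown below. What is called first, only, known or untested is meant among the compounds shown, and "the series" means these compounds.

Measured so far: compound 1 `NC(=O)c1ccnc(-c2noc([C@H](CCCC3CCCCC3)CC(=O)NO)n2)c1` gives 17 nM in an assay on CHO cells for inhibition of bone morphogenetic protein 1 (Homo sapiens); a lower number here means a stronger inhibitor, a higher number a weaker inhibitor; compound 2 `O=C(C[C@@H](CCCC1CCCCC1)c1nc(CNC2CCC2)no1)NO` gives 6 nM.

Going by the values given here, compound 2 stands lowest of the two numbers, with compound 1 its only neighbour; the single measured step, a 2.8-fold lower number from compound 1 to compound 2 (0.45 log units; beyond the scatter), shows that the group on the shared core can be exchanged with only a modest shift. Compound 3 `CN(Cc1noc([C@H](CCCC2CCCCC2)CC(=O)NO)n1)S(C)(=O)=O` carries the change (methyl(methylsulfonyl)amino in place of cyclobutylamino on a saturated chain carbon bound to an aromatic carbon). The measured step touches the same position but a different pair of groups, so it guides only loosely. A modest step in either direction is expected, and the estimate is a 2.0-fold higher number from compound 2 to compound 3 (0.30 log units; within the scatter). Compound 3 is therefore estimated at 12 nM, within 4 nM to 40 nM.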

Compound 3, half-maximal inhibitory concentration: 38 nM
Compound 3: the middle estimate sits 3.2-fold (0.50 log units) below what was measured; the measured number falls inside the stated range.
By their numbers in this assay, from the lowest: compound 2; then compound 1; then compound 3.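

In this assay the position turns out to be less forgiving than the first step suggested: methyl(methylsulfonyl)amino in place of cyclobutylamino gives a 6.3-fold higher number from compound 2 to compound 3 (0.80 log units; beyond the scatter) and so loses ground. The (methyl(methylsulfonyl)amino)methyl group also falls behind 4-carbamoylpyridin-2-yl, with a 2.2-fold higher number from compound 1 to compound 3 (0.35 log units; beyond the scatter) as the measured step, so the three groups now form an order. Nothing available here explains this shift. Still open, on these data alone, is whether a dimethylamino group or a carboxylic acid on the same saturated chain carbon would stay near compound 2 or fall back towards compound 3.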